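A few compounds are considered here, and "the series" means these few. Any claim that something is new, unique, unknown or untested is made for them only; others in the source may bear on it.

Of the compounds shown here, three that share a core have been measured in a physicochemical assay for acid dissociation. Compound 2 (`COc1ccc(Oc2ccc3c(NCCCNCc4cc(F)ccc4OC)ccnc3c2)cc1`) gives 9.28, level at the digits shown with compound 1 (`CC(C)(C)c1ccc(Oc2ccc3c(NCCCNCc4ccco4)ccnc3c2)cc1`), which gives 9.28. Compound 3 (`COc1cccc(CNCCCNc2ccnc3cc(Cc4ccc(F)cc4)ccc23)c1O`) gives 9.47, within the usual scatter of both. No two of these compounds differ in only one place, so the data show no direct size for a single change.

Compound 4 (`COc1ccc(F)cc1CNCCCNc1ccnc2cc(Cc3ccccc3)ccc12`) has not yet been measured. It departs from compound 2 at one place: benzyl in place of 4-methoxyphenoxy on an aromatic carbon, with benzyl in place of 4-methoxyphenoxy on an aromatic carbon. Compound 2 with 9.28 and compound 3 with 9.47 already lie within the scatter of each other while differing in more than one place, so no step beyond the scatter is expected in this assay. The estimated change is a number 0.07 log units higher from compound 2 to compound 4 (within the scatter), a small upward shift that stays within the scatter. For compound 4 the expected value is 9.35, with an estimated range of 9.05 to 9.65.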

Compound 4, acid dissociation constant: 9.47
Compound 4: middle estimate off by 0.12 log units, on the low side, within the range that was stated.
By their numbers in this assay, from the lowest: compounds 1, 2, 3 and 4 (each within the scatter of the next).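

In this assay the series now has its first comparison of compounds that differ in one place, and replacing 4-methoxyphenoxy with benzyl gives a number 0.19 log units higher from compound 2 to compound 4 (within the scatter) for this single change. At this position, on an aromatic carbon meta to a fused ring and para to a fused ring, losing both oxygen atoms of the leaving group therefore produces no step beyond the scatter. None of the evidence shown explains this result.

As far as these compounds go, it remains open whether a different kind of group at this position, such as an amine or a carboxylic acid, would give a step beyond the scatter. From the compounds shown here alone, it is also open whether the same replacement would give a similar step in a compound that differs from compound 2 elsewhere.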